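The compounds below may be only part of what the source reports. "The series", "measured", "known", "first", "only" and "open" are said of these compounds alone.

Measured so far in a functional assay on PC-3 cells (Homo sapiens) for inhibition, read by sulforhodamine B assay, with a stated time of 48 h; on this read-out higher numbers stand for weaker inhibition and lower numbers for stronger inhibition:
Compound 1 `COC(=O)[C@H]1C[C@@H](c2coc3ccccc3c2=O)N(c2ccccc2)O1`: > 60000 nM
Compound 2 `O=c1c([C@@H]2C[C@H](c3ccccc3)ON2c2ccccc2)coc2ccc(F)cc12`: 49000 nM

Compound 1 stands on no real number, only on a limit of the assay: the limit of > 60000 nM in this assay, at which 1 of the 2 values shown sits. This means that its true potency in this assay is not known. Within the data shown here, the only exact reading so far comes from compound 2, at 49000 nM.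

The compound of interest now is compound 3 `O=c1c([C@@H]2C[C@H](c3ccncc3)ON2c2ccccc2)coc2ccccc12`, which has not yet been tested. Compared with compound 1, it carries pyridin-4-yl in place of methoxycarbonyl on a saturated ring carbon. Among the measured compounds shown here, no measured pair of compounds shows what a swap of this kind does, so the expectation is only a rough one. For the measured compounds named here, with compound 2 at 49000 nM as the sole exact reading, compound 3 is expected to fall in much the same weak range. The expected change is an at least 1.3-fold lower number from compound 1 to compound 3 (0.12 log units; that floor lies within the scatter), a small move toward stronger inhibition that may not exceed the usual scatter. The assay may again report only a limit. For compound 3 the estimated value is 45000 nM, with an expected range from 20000 nM to 80000 nM.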

Compound 3, half-maximal inhibitory concentration: 46000 nM
Compound 3: middle estimate off by 1.0-fold (0.01 log units), on the low side, and the stated range covers the measured number.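

In this assay, pyridin-4-yl in place of methoxycarbonyl on this saturated ring carbon gives a real number where the parent gave none: compound 3 reads 46000 nM. The step is an at least 1.3-fold lower number from compound 1 to compound 3 (0.11 log units; that floor lies within the scatter), and its true size cannot be told because compound 1 stands on a limit and not on a number: the limit of > 60000 nM in this assay, at which 1 of the 3 values shown sits. So a six-membered aromatic ring with one nitrogen is tolerated at this carbon, in the sense that the reading stays in a weak range, but nothing shown proves that the swap moves inhibition beyond the scatter.

The compounds shown leave open whether any other group on this carbon, such as an amine or a carboxylic acid, could bring the reading into a much stronger range. Among these compounds, no pair with exact numbers at both ends yet isolates what a change at this carbon alone does, so the real effect of pyridin-4-yl remains unsized.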